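Fluoro for Chloro on the Aryl Amide of Compound 1

This account rests on a few compounds, and the source may have more. Where it says the series, first, only, none or still open, it means among the compounds named here.

Compound 1 `O=C(CN1CCC(c2cccc[n+]2[O-])CC1)Nc1cccc(Cl)c1`: 76%
Compound 2 `Cc1cccc(NC(=O)CN2CCC(c3cccc(O)c3)CC2)c1`: 66%
Compound 3 `Cc1cccc(NC(=O)CN2CCC(c3cccc(C#N)n3)CC2)c1`: 42%

In a functional assay on HEK293 cells for agonist activity at D(4) dopamine receptor (Homo sapiens), read by FLIPR (a higher number here means a larger maximal response, a lower number a smaller maximal response), compound 1 holds the highest of the three numbers: compound 2 lies within the scatter of it, while compound 3 falls beyond it. Within the data shown here, the one measured step, a number 24 percentage points lower from compound 2 to compound 3 (beyond the scatter), changes the group on the saturated ring carbon and says nothing about the six-membered aromatic ring of carbon only. Compound 4 `O=C(CN1CCC(c2cccc[n+]2[O-])CC1)Nc1cccc(F)c1` differs from compound 1 by fluoro in place of chloro on an aromatic carbon. Among the measured compounds shown here, with no measured step on that ring, the size of the move is uncertain, and a change within the scatter is expected, a number 4 percentage points lower from compound 1 to compound 4 (within the scatter). Compound 4 is therefore estimated at 72%, with a range from 58% to 86%.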

Compound 4, largest response reached (reported as efficacy), in percent of the reference or control that the assay uses: 70%
The estimate for compound 4 lay 2 percentage points above the measured number; low and high end bracket the measured number.
By their numbers in this assay, from the lowest: compound 3; then compounds 2, 4 and 1 (each within the scatter of the next).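

Among these compounds, compound 4 supplies the first measured step on the six-membered aromatic ring of carbon only: in this assay, fluoro in place of chloro gives a number 6 percentage points lower from compound 1 to compound 4 (within the scatter). At this place, meta to a large group, the two halogens cannot be told apart in this read-out. No available evidence bears on the reason for this result.

Going by these compounds, whether the same place accepts a methoxy group, an amine or a carboxylic acid stays open. So does whether this exchange reads the same with another group on the saturated ring carbon.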